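A few compounds are considered here, and "the series" means these few. Any claim that something is new, unique, unknown or untested is made for them only; others in the source may bear on it.

Measured so far in a functional assay on HeLa cells (Homo sapiens) for cytotoxicity, read by MTT assay, with a stated time of 2 days, tested at 0.1 uM; on this read-out higher numbers stand for a weaker effect at the one concentration tested and lower numbers for a stronger effect:
compound 1, `CC(=O)c1cc(-c2ccc(F)cc2)cc2cc(-c3ccccc3)[nH]c12` — compound 1 gives 90.3%
compound 2, `COc1ccc(-c2cc(C(C)=O)c3[nH]c(-c4ccccc4)cc3c2)cc1` — compound 2 gives 87.9%

Both numbers sit high on this read-out, so at the concentration tested the effect of either compound is weak. For the measured compounds named here, compound 2 stands at the same level as compound 1: the single step between them, a number 2.4 percentage points lower from compound 1 to compound 2 (within the scatter), lies within the scatter, so no order between the two can be read from it.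

Compound 3, `CC(=O)c1cc(/C=C/c2ccccc2)cc2cc(-c3ccccc3)[nH]c12`, is the next compound and differs from compound 2 in one place: 2-phenylethenyl in place of 4-methoxyphenyl on an aromatic carbon. Going by the values given here, the only measured step, from compound 1 to compound 2, also exchanges one group on that same aromatic carbon, and it produced no change beyond the scatter. Among the compounds with values here, it is the one piece of evidence that bears on the new step, and it gives no direction. A second exchange at this position is therefore expected to leave the number where it is, with an estimated step of a number 0.9 percentage points lower from compound 2 to compound 3 (within the scatter). For compound 3 the estimate in this assay is 87%, with an expected range from 72% to 98%.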

Compound 3, a percentage reported as activity, at one concentration (the size of the read-out at that concentration, not a potency): 99.1%
The estimate for compound 3 lay 12.1 percentage points below the measured number; the whole stated range lies below it.
By their numbers in this assay, from the lowest: compounds 2, 1 and 3 (each within the scatter of the next, the first and the last beyond it).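

In this assay, this aromatic carbon now yields a step beyond the scatter, a number 11.2 percentage points higher from compound 2 to compound 3 (beyond the scatter), so the position is not wholly indifferent to the group it carries, and the direction is towards a weaker effect at the one concentration tested. The shift holds only against 4-methoxyphenyl: set against 4-fluorophenyl, the same 2-phenylethenyl group gives a number 8.8 percentage points higher from compound 1 to compound 3 (within the scatter), which allows no order between those two compounds, so no ranking of all three groups follows. The exchange brings in a double bond outside aromatic rings and removes the oxygen of the methoxy group in one step, and no measurement available here accounts for the shift or separates these two parts of the change.

As far as these compounds go, all three compounds carry an aromatic ring at this carbon and all stay high on the read-out, so it remains open whether any group here can bring the number clearly down. An amine, a carboxylic acid or a longer saturated chain at this position would test that, and a read at a further concentration would show whether the effect stays as weak there as at the one concentration tested.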